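A few compounds are considered here, and "the series" means these few. Any claim that something is new, unique, unknown or untested is made for them only; others in the source may bear on it.

Measured so far in an ADME assay on the whole organism (Rattus norvegicus, strain Sprague-Dawley) for pharmacokinetics, using cassette dosing, at a dose of 1 mg/kg by the oral route; on this read-out lower numbers stand for lower oral bioavailability and higher numbers for higher oral bioavailability:
Compound 1 `O=C(Nc1ccc2[nH]c(=O)oc2c1)C(=O)N1CCN(c2ccc(Cl)c(F)c2)CC1` gives 28.2%
Compound 2 `C[C@@H]1CN(C(=O)C(=O)Nc2ccc3[nH]c(=O)oc3c2)CCN1c1ccc(Cl)cc1` gives 52.6%
Compound 3 `C[C@@H]1CN(C(=O)C(=O)Nc2ccc3[nH]c(=O)oc3c2)CCN1c1ccc(F)c(F)c1` gives 25.3%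

Compound 3 at 25.3% sits within the scatter of compound 1, and on these numbers it lies beyond the scatter from compound 2, which gives 52.6%. Compound 4 `C[C@@H]1CN(C(=O)C(=O)Nc2ccc3[nH]c(=O)oc3c2)CCN1c1ccc(Cl)c(F)c1` differs from compound 3 in one place (chloro in place of fluoro on an aromatic carbon): chloro in place of fluoro on an aromatic carbon, so that 3,4-difluorophenyl becomes 4-chloro-3-fluorophenyl. Going by the values given here, the one measured step that bears on this is the exchange of 4-chlorophenyl for 3,4-difluorophenyl (a number 27.3 percentage points lower from compound 2 to compound 3 (beyond the scatter)), a fall beyond the scatter. Compound 4 regains the chloro of compound 2 yet keeps one fluoro group, so part of that fall is expected to come back. Compound 1 also carries 4-chloro-3-fluorophenyl and gives 28.2% which keeps the expectation modest. A rise in this assay is therefore expected (a number 14.7 percentage points higher from compound 3 to compound 4 (beyond the scatter)), smaller than the measured fall. The estimate for compound 4 is 40% (expected range 24% to 58%).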

Compound 4, oral bioavailability: 32%
Compound 4: the middle estimate sits 8 percentage points above what was measured; the range from low to high includes it.
By their numbers in this assay, from the lowest: compounds 3, 1 and 4 (each within the scatter of the next); then compound 2.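

In this assay, chloro in place of fluoro on this aromatic carbon, para to a large group, gives a number 6.7 percentage points higher from compound 3 to compound 4 (within the scatter), so this exchange does not separate 3,4-difluorophenyl from 4-chloro-3-fluorophenyl, while fluoro in place of hydrogen on an aromatic carbon gives a number 20.6 percentage points lower from compound 2 to compound 4 (beyond the scatter), which sets 4-chlorophenyl apart from both fluorinated rings on the methylated core. Methyl in place of hydrogen on a saturated ring carbon gives a number 3.8 percentage points higher from compound 1 to compound 4 (within the scatter), so with 4-chloro-3-fluorophenyl in place this methyl shows no change beyond the scatter, and the high value of compound 2 is not a general feature of the methylated compounds. No measurement on hand accounts for any of these steps.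

The compounds shown leave open whether a larger group at this aromatic carbon, such as trifluoromethyl or methoxy, would behave as chloro and fluoro do here. They also leave open how a nitrile would fare there, and whether the fluoro group ortho to this carbon could give way to hydrogen with the same outcome.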